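The source may hold more compounds than are shown below. What is called first, only, known or untested is meant among the compounds shown, and "the series" means these compounds.

Measured compounds:
Compound 1 `C=CC1=C(C(=O)NCCC)C(c2ccc(F)cc2)OC1` in a functional assay on QGY7701 cells (Homo sapiens) for cytotoxicity, read by MTT assay, with a stated time of 24 h (a higher number here means a weaker inhibitor, a lower number a stronger inhibitor), gives > 100000 nM, which is a limit of the assay and not a number.
Compound 2 `C=CC1=C(C(=O)NCc2ccccc2)C(c2ccc(OC)c(OC)c2)OC1` in this assay gives > 100000 nM, again a limit of the assay rather than a number.

Compound 2 therefore stands at the upper end of what this assay reports, with no numerical half-maximal inhibitory concentration. Among the measured compounds shown here, the same holds for the only other measured compound, so nothing measured separates the two; both sit at the limit of > 100000 nM in this assay, at which 2 of the 2 values shown sit.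

Compound 3 `C=CC1=C(C(=O)NCc2ccccc2)C(c2ccc(OC)cc2)OC1` differs from compound 2 in one place: hydrogen in place of methoxy on an aromatic carbon. The amide chain and the rest of the shared core are unchanged.

For the measured compounds named here, no step between measured compounds is available to calibrate this change. Because compound 2 sits at the limit of > 100000 nM in this assay, at which 2 of the 2 values shown sit, the most that can be said is that compound 3 is expected to remain near or at that limit; a step beyond the scatter toward stronger inhibition is not anticipated. The step of a number no higher from compound 2 to compound 3 (the limit leaves the size open) is expected to be none beyond the scatter. For compound 3 the estimate is 100000 nM, with a range from 30000 nM to 300000 nM, and a limit rather than a number is the likelier outcome.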

Compound 3, half-maximal inhibitory concentration: > 100000 nM
Compound 3: a limit, no number (the forecaster's own chance of this, stated with the estimate: 80%); the middle value sits exactly at the limit.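

Compound 2 and compound 3 both end at a limit of the assay rather than at a number, so no step can be read for hydrogen in place of methoxy: the limit of > 100000 nM in this assay, at which 3 of the 3 values shown sit.

The compounds shown leave open whether any change to the shared core or the amide chain would give a numerical half-maximal inhibitory concentration in this assay.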